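Sulfonamide series: methylsulfonyl step transferred to chloro core

The source may report more compounds than this note shows. Statements on the series, on what has been measured and on what is new or still open speak of the compounds shown alone.

Measured compounds, with their half-maximal inhibitory concentrations:
- compound 1, `N#Cc1c[nH]c2c(NS(=O)(=O)c3ccc(N)cc3)cccc12`: 4.4 ug/mL
- compound 2, `CS(=O)(=O)Nc1ccc(S(=O)(=O)Nc2cccc3c(C#N)c[nH]c23)cc1`: 15 ug/mL
- compound 3, `Nc1ccc(S(=O)(=O)Nc2cccc3c(Cl)c[nH]c23)cc1`: 10 ug/mL

All three numbers come from a functional assay on KB cells (nasopharynx, Homo sapiens) for antiproliferative activity; on this read-out higher numbers stand for weaker inhibition and lower numbers for stronger inhibition. Compound 1 sits at the strong end of the three; compound 2 and compound 3 lie within the scatter of each other, so no order is drawn between them.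

Two changes are covered. The first is methylsulfonyl in place of hydrogen on a nitrogen on an aromatic ring, which gave a 3.4-fold higher number from compound 1 to compound 2 (0.53 log units; beyond the scatter). The second, between the two cores, is chloro in place of cyano on an aromatic carbon, which gave a 2.3-fold higher number from compound 1 to compound 3 (0.36 log units; beyond the scatter).

Compound 4, `CS(=O)(=O)Nc1ccc(S(=O)(=O)Nc2cccc3c(Cl)c[nH]c23)cc1`, is not yet measured. It differs from compound 3 by methylsulfonyl in place of hydrogen on a nitrogen on an aromatic ring. This is the same change as that from compound 1 to compound 2, made on the core of compound 3 instead of the core of compound 1; the place around it reads the same in both cases. The change occurs twice among these four compounds, only once with a measured outcome.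

For compound 4 a step of about a 3.0-fold higher number from compound 3 to compound 4 (0.48 log units; beyond the scatter) is expected, set beside the measured step of a 3.4-fold higher number from compound 1 to compound 2 (0.53 log units; beyond the scatter) and resting on a single precedent, so the range is kept wide. Compound 4 is estimated at 30 ug/mL in this assay, with a span from 12 ug/mL to 70 ug/mL.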

Compound 4, half-maximal inhibitory concentration: 12 ug/mL
Beside the measured number, compound 4's estimate is 2.5-fold (0.40 log units) above it, and the stated range covers the measured number.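

In this assay, the size of the methylsulfonyl step did not carry from the core of compound 1 to the core of compound 3, where the change gave a 1.2-fold higher number from compound 3 to compound 4 (0.08 log units; within the scatter), and the two outcomes differ: the same change on two cores in this assay, a 3.4-fold higher number (0.53 log units; beyond the scatter) from compound 1 to compound 2 and a 1.2-fold higher number (0.08 log units; within the scatter) from compound 3 to compound 4, 2.8-fold (0.45 log units) apart, beyond the scatter of two such steps

Chloro in place of cyano, read with methanesulfonamido in place of amino, gave a 1.3-fold lower number from compound 2 to compound 4 (0.10 log units; within the scatter), so this change also depends on what stands elsewhere in the molecule: the same change on two cores in this assay, a 2.3-fold higher number (0.36 log units; beyond the scatter) from compound 1 to compound 3 and a 1.3-fold lower number (0.10 log units; within the scatter) from compound 2 to compound 4, 2.8-fold (0.45 log units) apart, beyond the scatter of two such steps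

Both gaps come from the same closed set of four compounds, so they are one non-additive result seen from two sides; it shows that a step measured on one core was a poor guide to the other here, but it does not show why, nor whether the same holds anywhere else in the series.

Still open, going by these compounds, is how the step behaves on these two cores with other groups on the amino nitrogen, such as acetyl or the longer ethylsulfonyl. Also open, on these data alone, is whether bromo or methyl in place of cyano would follow compound 3 or compound 1 when paired with amino and methanesulfonamido.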